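Pentyl replaces 2-fluorophenyl on the triazole of compound 3

The compounds below may be only part of what the source reports. "The series", "measured", "known", "first", "only" and "open" are said of these compounds alone.

Of the compounds shown here, three have been measured in an ADME assay on HEK293 cells (Homo sapiens) for cytotoxicity, read by sulforhodamine B assay, with a stated time of 48 h, tested at 10 uM; on this read-out lower numbers stand for less inhibition and higher numbers for more inhibition at the one concentration tested (going by the name of the read-out). Compound 1 `COc1nc2ccc(Br)cc2cc1C(c1ccccc1)n1cc(-c2ccccc2)nn1` gives 8.25%. Compound 2 `CCCCc1cn(C(c2ccccc2)c2cc3cc(Br)ccc3nc2OC)nn1` gives -3.47%. Compound 3 `COc1nc2ccc(Br)cc2cc1C(c1ccccc1)n1cc(-c2ccccc2F)nn1` gives 3.97%, which places it second highest of the three; its nearest neighbour is compound 1, and its furthest is compound 2, both within the scatter of compound 3.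

The unmeasured compound 4 `CCCCCc1cn(C(c2ccccc2)c2cc3cc(Br)ccc3nc2OC)nn1` differs from compound 3 in one place: pentyl in place of 2-fluorophenyl on an aromatic carbon. The step that bears most directly on this change is a number 11.7 percentage points lower from compound 1 to compound 2 (beyond the scatter), where a chain replaced an aromatic ring at the same place. The reverse kind of change is seen in a number 7.4 percentage points higher from compound 2 to compound 3 (within the scatter). The chain-bearing compound 2 thus sits at the low end of the three, while the two ring-bearing compounds sit within the scatter of each other.

Compound 4 carries a chain one carbon longer than compound 2 and is therefore expected to land near compound 2, with an estimated step of a number 6 percentage points lower from compound 3 to compound 4 (within the scatter). The estimate for compound 4 is -2%, with a range from -12% to 8%.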

Compound 4, a percentage reported as inhibition, at one concentration (the size of the read-out at that concentration, not a potency): -2%
Compound 4: middle estimate and measured number agree at the digits printed; the measured number falls inside the stated range.
By their numbers in this assay, from the lowest: compounds 2, 4, 3 and 1 (each within the scatter of the next, the first and the last beyond it).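

In this assay the chain can be extended at this position with little consequence: the reading shifts by a number 1.5 percentage points higher from compound 2 to compound 4 (within the scatter) when butyl gives way to pentyl. Exchange of ring for chain now has a second case, as a number 10.3 percentage points lower from compound 1 to compound 4 (beyond the scatter) lies beyond the scatter like the earlier butyl result, but compound 3 goes against a clean split between rings and chains, since a number 6 percentage points lower from compound 3 to compound 4 (within the scatter) leaves 2-fluorophenyl unseparated from pentyl. No measurement on hand accounts for these differences.

Open, from the compounds shown here alone, is whether a longer chain such as octyl, or a pentyl chain ending in an amine or a carboxylic acid, would read like compound 2 and compound 4 at this position. Also open, going by these compounds, is whether these readings would hold at other concentrations in this assay and whether the gap between phenyl and the chains would widen there.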